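Swapping the benzylamine aryl group for a furan

This account rests on a few compounds, and the source may have more. Where it says the series, first, only, none or still open, it means among the compounds named here.

Measured compounds:
- compound 1, `CC(C)Cc1ccc2c(NCCCNCc3ccco3)ccnc2c1`: 4200 nM
- compound 2, `COc1cccc(Oc2ccc3c(NCCCNCc4cc(F)ccc4OC)ccnc3c2)c1`: 14500 nM

In a physicochemical assay for solubility, with a stated time of 18 h, at pH 7.4 (a higher number here means a more soluble compound, a lower number a less soluble compound), compound 2 gives the higher of the two numbers; its value stands above that of compound 1 by more than the usual scatter. Compound 3, `COc1cccc(Oc2ccc3c(NCCCNCc4ccco4)ccnc3c2)c1`, is not yet measured. It differs from compound 2 in one place: furan-2-yl in place of 5-fluoro-2-methoxyphenyl on a saturated chain carbon bound to an amine nitrogen. For the measured compounds named here, no measured pair shows this exact change, so its size is unknown. The expected step of a 1.2-fold higher number from compound 2 to compound 3 (0.07 log units; within the scatter) is modest and not clearly beyond the scatter. Compound 3 is therefore estimated at 17000 nM in this assay, with a range from 6000 nM to 45000 nM.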

Compound 3, solubility: 14500 nM
Compound 3: the middle estimate sits 1.2-fold (0.07 log units) above what was measured, and the stated range covers the measured number.
By their numbers in this assay, from the lowest: compound 1; then compounds 2 and 3 (each within the scatter of the next).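

In this assay, furan-2-yl in place of 5-fluoro-2-methoxyphenyl on a saturated chain carbon bound to an amine nitrogen gives no change at the digits printed from compound 2 to compound 3 (within the scatter), so here a five-membered aromatic ring reads the same as a six-membered one. With furan-2-yl kept, 3-methoxyphenoxy in place of isobutyl on an aromatic carbon gives a 3.5-fold higher number from compound 1 to compound 3 (0.54 log units; beyond the scatter), so among these three compounds only the aromatic-carbon change moves the number beyond the scatter. No available measurement explains either result. Going by these compounds, whether an amine or a carboxylic acid in place of furan-2-yl would also leave the number unchanged remains open.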